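The source may hold more compounds than are shown below. What is called first, only, known or untested is meant among the compounds shown, and "the series" means these compounds.

Among the compounds with values here, compound 2 `COc1ccc(C(=O)/C=C/c2cc(-c3cc(OC)c(OC)c(OC)c3)n[nH]2)cc1` is one of two compounds measured in a functional assay on KM12 cells (Homo sapiens) for cytotoxicity, read by sulforhodamine B assay, with a stated time of 48 h, tested at 10 uM; on this read-out higher numbers stand for a weaker effect at the one concentration tested and lower numbers for a stronger effect. In that test compound 2 gives -88%, which is the lowest of the two numbers and therefore the stronger effect. Within the data shown here, the only other measured compound is compound 1 `COc1cc(-c2cc(/C=C/C(=O)c3ccc(N)cc3)[nH]n2)cc(OC)c1OC`, which in this assay gives -67%. Among the measured compounds shown here, the one step available is a number 21 percentage points lower from compound 1 to compound 2 (beyond the scatter), so the pair with methoxy in place of amino on an aromatic carbon moved beyond the scatter but only modestly.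

Compound 3 `COc1cc(-c2cc(/C=C/C(=O)c3ccc(F)c(F)c3)[nH]n2)cc(OC)c1OC` has not yet been measured. It differs from compound 2 by 3,4-difluorophenyl in place of 4-methoxyphenyl on a carbonyl carbon. For the measured compounds named here, no measured step involves a fluorine group or touches the ring on the carbonyl carbon, so the earlier step gives only a loose sense of scale: a single change at the edge of this shared core moved the number by a modest amount. On that basis the step from compound 2 to compound 3 in this assay is expected to be small, a number 13 percentage points higher from compound 2 to compound 3 (beyond the scatter), most likely within or just beyond the scatter and if anything toward a weaker effect. Compound 3 is therefore expected to give about -75% in this assay, with a likely range from -100% to -40%.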

Compound 3, a percentage reported as activity, at one concentration (the size of the read-out at that concentration, not a potency): 3%
Compound 3: middle estimate off by 78 percentage points, on the low side; the measured number lies above the stated range.
By their numbers in this assay, from the lowest: compound 2; then compound 1; then compound 3.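

In this assay, within the data shown here, the group on the carbonyl carbon turns out to matter far more than the earlier compounds showed: 3,4-difluorophenyl in place of 4-methoxyphenyl gives a number 91 percentage points higher from compound 2 to compound 3 (beyond the scatter) and, in place of 4-aminophenyl, it gives a number 70 percentage points higher from compound 1 to compound 3 (beyond the scatter). Both of these steps are large, whereas the earlier swap of amino for methoxy on the same ring, a number 21 percentage points lower from compound 1 to compound 2 (beyond the scatter), was only modest, so this position allows one change with a modest shift in the number and another with a large loss of effect at the one concentration tested. Nothing available here explains why the difluorinated ring behaves so differently.

The compounds shown leave open whether the two fluorine atoms lower the effect or whether the loss of a methoxy or amino group does, and an unsubstituted phenyl ring or a 4-fluorophenyl ring at this position would help to separate the two. Other groups on the ring, such as hydroxyl or dimethylamino, also remain open, as does whether the same pattern holds at concentrations other than the one tested.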